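From Triazole Amide to Imidazole Diamide on a Lactam Chain

This account rests on a few compounds, and the source may have more. Where it says the series, first, only, none or still open, it means among the compounds named here.

Compound 1 `COC(=O)c1ncn(CC=C2OC(=O)C(OCc3ccccc3)=C2OCc2ccccc2)c1C(=O)OC` and compound 2 `NC(=O)c1ncn(CCC2(O)NC(=O)C(OCc3ccccc3)=C2OCc2ccccc2)n1` are the two compounds with measured values. In a functional assay on MIA PaCa-2 cells (Homo sapiens) for antiproliferative activity, read by MTT assay, with a stated time of 72 h (a higher number here means a weaker inhibitor, a lower number a stronger inhibitor), compound 1 gives 33000 nM. For compound 2 the result in this assay is only a limit of the assay, > 100000 nM, and not a number. For the measured compounds named here, compound 2 thus sits at the limit of > 100000 nM in this assay, at which 1 of the 2 values shown sits, so where it stands among the measured values is known only as that limit, and compound 1 is the only one with a number. Going by the values given here, no step between two measured compounds that differ in a single place is available, so nothing shows how a change of this kind has moved the read-out.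

Compound 3 `NC(=O)c1ncn(CCC2(O)NC(=O)C(OCc3ccccc3)=C2OCc2ccccc2)c1C(N)=O` is not yet measured. It differs from compound 2 by 4,5-dicarbamoyl-1H-imidazol-1-yl in place of 3-carbamoyl-1H-1,2,4-triazol-1-yl on a saturated chain carbon, two bonds along the chain from a saturated ring carbon. Since compound 2 sits at the limit of > 100000 nM in this assay, at which 1 of the 2 values shown sits, the expected step is a number no higher from compound 2 to compound 3 (the limit leaves the size open), which means no movement beyond the scatter that a limit allows one to judge. Compound 3 is therefore expected to give about 100000 nM in this assay, with a range from 30000 nM to 300000 nM, and a fair chance that only a limit is reported again.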

Compound 3, half-maximal inhibitory concentration: > 100000 nM
Compound 3: only a limit was reported (the forecaster's own chance of this, stated with the estimate: 60%); the middle value sits exactly at the limit.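

In this assay compound 3 gives > 100000 nM, a limit of the assay and not a number. Compound 2 also stands at a limit, so no step can be read between compound 2 and compound 3: the limit of > 100000 nM in this assay, at which 2 of the 3 values shown sit.

The compounds shown leave open whether 4,5-dicarbamoyl-1H-imidazol-1-yl and 3-carbamoyl-1H-1,2,4-triazol-1-yl differ at all in this read-out.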